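Notes on a methyl-to-ring exchange at the core

The source may hold more compounds than are shown below. What is called first, only, known or untested is meant among the compounds shown, and "the series" means these compounds.

Two compounds carry the shared core with a methoxypyridine attached. Compound 1 `CNc1nc2c(-c3ccnc(OC)c3)cnn2cc1C` has a methylamino group on the core; compound 2 `COc1cc(-c2cnn3cc(OC)c(C)nc23)ccn1` has a methoxy group in that position instead. In an assay on isolated protein for inhibition of activin receptor type-2A (Homo sapiens), read by 33P incorporation, with a stated time of 20 min, in the presence of a further agent that is not named here (a lower number here means a stronger inhibitor, a higher number a weaker inhibitor), compound 1 gives 1300 nM; compound 2 gives 1200 nM. Compound 2 has the lowest of the two numbers, yet the gap to compound 1 sits inside the usual scatter, so the two are treated as alike.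

Compound 3 `COc1cc(-c2cnn3cc(OC)c([C@H]4COC(C)(C)C4)nc23)ccn1` comes from compound 2 by the following change: a group of 7 heavy atoms (6 carbon, 1 oxygen; one five-membered non-aromatic ring with 1 hetero atom) in place of one carbon atom, on an aromatic carbon

Among the compounds with values here, no pair of measured compounds shows such a step, so the data offer no direct precedent. The expectation is a modest gain, a step from compound 2 to compound 3 of roughly a 3.0-fold lower number from compound 2 to compound 3 (0.48 log units; beyond the scatter), held loosely. Compound 3 is therefore estimated at 400 nM in this assay, with a range from 100 nM to 1600 nM.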

Compound 3, half-maximal inhibitory concentration: 4100 nM
Beside the measured number, compound 3's estimate is 10-fold (1.01 log units) below it; measured number above the stated range.
By their numbers in this assay, from the lowest: compounds 2 and 1 (each within the scatter of the next); then compound 3.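

At this position, on an aromatic carbon next to the ring nitrogen and ortho to a methoxy group, the methyl group is not a neutral placeholder. In this assay, replacing it with the five-membered non-aromatic ring gives a 3.4-fold higher number from compound 2 to compound 3 (0.53 log units; beyond the scatter), a modest loss that goes beyond the scatter. The entering ring adds one hydrogen-bond acceptor and a defined stereocentre, but the data offer no measurement that explains the direction of this step.

On these data alone, it remains open whether an isopropyl group or a cyclopentyl ring, which has no ring oxygen, would read like methyl or like the larger ring here, and how the opposite stereoisomer would compare. Also open, as far as these compounds go, is whether the same exchange on compound 1, with its methylamino group, would give a step of similar size.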